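Phenoxy beta-lactam series: nitro and hydroxy substituted aryl analogue

The source may hold more compounds than are shown below. What is called first, only, known or untested is meant among the compounds shown, and "the series" means these compounds.

Compound 1 `COc1ccc([C@@H]2[C@H](Oc3ccccc3)C(=O)N2c2cc(OC)c(OC)c(OC)c2)cc1` is the reference point of the three measured compounds. In a functional assay on MCF7 cells (Homo sapiens) for antiproliferative activity, read by MTT assay, with stated times of 24 h and 72 h (on this read-out higher numbers stand for weaker inhibition and lower numbers for stronger inhibition), compound 1 gives 35000 nM, the lowest of the three numbers. Compound 3 `COc1ccc([C@@H]2[C@H](Oc3ccccc3)C(=O)N2c2cc(OC)c(OC)c(OC)c2)cc1[N+](=O)[O-]` gives 69000 nM, and compound 2 `COc1cc(N2C(=O)[C@@H](Oc3ccccc3)[C@H]2c2ccc3ccccc3c2)cc(OC)c1OC` gives 282000 nM.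

The measured steps set the scale. The step of a 2.0-fold higher number from compound 1 to compound 3 (0.29 log units; within the scatter) lies within the scatter, so adding a nitro group on the aromatic ring attached to the saturated ring carbon left the number essentially unchanged. The step of an 8.1-fold higher number from compound 1 to compound 2 (0.91 log units; beyond the scatter) is a larger change of the same aromatic group and weakened inhibition modestly.

Compound 4 `COc1cc([N+](=O)[O-])c([C@@H]2[C@H](Oc3ccccc3)C(=O)N2c2cc(OC)c(OC)c(OC)c2)cc1O` differs from compound 1 by a group of 12 heavy atoms (7 carbon, 1 nitrogen, 4 oxygen; one six-membered aromatic ring of carbon only) in place of a group of 8 heavy atoms (7 carbon, 1 oxygen; one six-membered aromatic ring of carbon only), on a saturated ring carbon. For the measured compounds named here, the closest precedent is the step from compound 1 to compound 3, which carried the nitro group and stayed within the scatter; no measured step covers the added hydroxyl. The change is larger than that of compound 3 but smaller in kind than the swap to compound 2, so a small weakening at most is expected, a 1.6-fold higher number from compound 1 to compound 4 (0.20 log units; within the scatter), with a fair chance of no step beyond the scatter. Compound 4 is therefore estimated at 55000 nM, in the range 20000 nM to 150000 nM.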

Compound 4, half-maximal inhibitory concentration: 59000 nM
The estimate for compound 4 lay 1.1-fold (0.03 log units) below the measured number, within the range that was stated.
By their numbers in this assay, from the lowest: compounds 1, 4 and 3 (each within the scatter of the next); then compound 2.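

On the saturated ring carbon next to the ring nitrogen, the aryl group of compound 4, carrying both a nitro group and a hydroxyl, gives no readable change in this assay: the steps are a 1.7-fold higher number from compound 1 to compound 4 (0.23 log units; within the scatter) and a 1.2-fold lower number from compound 3 to compound 4 (0.07 log units; within the scatter). The naphthalen-2-yl group of compound 2 stays apart, with a 4.8-fold lower number from compound 2 to compound 4 (0.68 log units; beyond the scatter), so among the four groups shown, it alone separates from the others at this position. No accompanying measurement bears on this result.

Open, as far as these compounds go, is whether an amine or a carboxylic acid on this aryl ring would also stay within the scatter of compound 1. Also open, from the compounds shown here alone, is how far the number depends on the phenoxy group, which is constant across all four compounds.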